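Swapping benzyl for 4-fluorophenyl on compound 1

The source may report more compounds than this note shows. Statements on the series, on what has been measured and on what is new or still open speak of the compounds shown alone.

In a toxicity assay on cells (Macrophage, Mus musculus, strain BALB/c) for cytotoxicity, read by MTT assay (a lower number here means a stronger inhibitor, a higher number a weaker inhibitor), compound 1 `C=CCOc1cc(OC)c(C(=O)/C=C/Cc2ccccc2)c(OCC=C)c1` gives 14800 nM. Compound 2 `C=CCOc1cc(/C=C/C(=O)c2c(O)cc(O)cc2OC)cc(OCC=C)c1Br`, which has a different structure, gives 11500 nM. Within the data shown here, these two numbers lie within the usual scatter of each other, so compound 1 stands level with the only other measured compound. Compound 3 `C=CCOc1cc(OC)c(C(=O)/C=C/c2ccc(F)cc2)c(OCC=C)c1` differs from compound 1 by carrying 4-fluorophenyl in place of benzyl on a double-bonded chain carbon bound to a double-bonded chain carbon. Among the measured compounds shown here, no measured pair shows this change, so only a small move toward a lower number is expected in this assay. The expected step is a 1.5-fold lower number from compound 1 to compound 3 (0.17 log units; within the scatter), close to the scatter. For compound 3 the estimate is 10000 nM, with an expected range of 4000 nM to 25000 nM.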

Compound 3, half-maximal inhibitory concentration: 13800 nM
Compound 3: middle estimate off by 1.4-fold (0.14 log units), on the low side; the range from low to high includes it.
By their numbers in this assay, from the lowest: compounds 2, 3 and 1 (each within the scatter of the next).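

Putting 4-fluorophenyl in place of benzyl on a double-bonded chain carbon bound to a double-bonded chain carbon gives a 1.1-fold lower number from compound 1 to compound 3 (0.03 log units; within the scatter) in this assay and so the two compounds stand level. Among these compounds, this is the first direct reading of a change at this place, and with the rest of the core of compound 1 held fixed, this swap does not separate the two compounds. Nothing at hand explains why the two groups read alike.

From the compounds shown here alone, whether an amine or a carboxylic acid at this place would read differently stays open. So does the effect of a longer chain carrying the phenyl ring.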